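The compounds below may be only part of what the source reports. "The series", "measured", "known", "first", "only" and "open" are said of these compounds alone.

Compound 3 `Cc1ccc(-c2cs/c(=N/NC(=O)CSc3ncccn3)n2-c2ccccc2)cc1` stands highest of the three numbers in a functional assay on C6 cells (Rattus norvegicus) for cytotoxicity, read by MTT assay, with a stated time of 24 h, tested at 200 ug/mL (on this read-out higher numbers stand for a weaker effect at the one concentration tested and lower numbers for a stronger effect), where compound 3 gives 43.7%. Among the measured compounds shown here, compound 1 `Cc1nnc(SCC(=O)N/N=c2/scc(-c3ccc(Cl)cc3)n2-c2ccccc2)s1` gives 29% and compound 2 `COc1ccc(-c2cs/c(=N/NC(=O)CSc3nnc(C)s3)n2-c2ccccc2)cc1` gives 22.2%; the one step among them, a number 6.8 percentage points lower from compound 1 to compound 2 (within the scatter), lies within the scatter. Compound 4 `Cc1ccc(-c2cs/c(=N/NC(=O)CSc3nnc(C)s3)n2-c2ccccc2)cc1` differs from compound 3 by 5-methyl-1,3,4-thiadiazol-2-yl in place of pyrimidin-2-yl on a sulfur. For the measured compounds named here, no measured step covers this change directly: compound 1 and compound 2 carry the 5-methyl-1,3,4-thiadiazol-2-yl group but differ from compound 4 elsewhere as well, so their values are only a rough guide. Both stand beyond the scatter under compound 3, so a step down toward them is expected, estimated as a number 13.7 percentage points lower from compound 3 to compound 4 (beyond the scatter). Compound 4 is expected to give 30% in this assay, within the range 18% to 44%.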

Compound 4, a percentage reported as activity, at one concentration (the size of the read-out at that concentration, not a potency): 13.3%
Compound 4: middle estimate off by 16.7 percentage points, on the high side; the whole stated range lies above it.
By their numbers in this assay, from the lowest: compounds 4, 2 and 1 (each within the scatter of the next, the first and the last beyond it); then compound 3.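

In this assay, among the compounds shown here, the change on the sulfur now has a direct reading, with 5-methyl-1,3,4-thiadiazol-2-yl in place of pyrimidin-2-yl giving a number 30.4 percentage points lower from compound 3 to compound 4 (beyond the scatter) and making this the largest step so far. With that group held fixed, the change on the aromatic carbon gives a number 8.9 percentage points lower from compound 2 to compound 4 (within the scatter) for methyl in place of methoxy and a number 15.7 percentage points lower from compound 1 to compound 4 (beyond the scatter) for methyl in place of chloro. Nothing available explains the size of the step on the sulfur.

Going by these compounds, whether that step holds with chloro or methoxy on the aromatic carbon remains open. So does the reading for a phenyl group or a butyl chain on the sulfur.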